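The source may report more compounds than this note shows. Statements on the series, on what has been measured and on what is new or still open speak of the compounds shown alone.

In an ADME assay on THP-1 cells (Homo sapiens) for cytotoxicity, read by flow cytometry and propidium iodide staining, with a stated time of 72 h (on this read-out lower numbers stand for stronger inhibition and higher numbers for weaker inhibition), compound 1 (`COc1c(-c2cccc(F)c2)oc2ccc(NC(C)=O)cc2c1=O`) gives > 125000 nM, which is a limit of the assay and not a number. Compound 2 (`COc1c(-c2ccc(F)cc2)oc2ccc(NC(C)=O)cc2c1=O`) gives > 125000 nM, which is also a limit. All the evidence so far is therefore (the limit of > 125000 nM in this assay, at which 2 of the 2 values shown sit). Among the measured compounds shown here, the one measured step is a step that the two limits leave unreadable from compound 1 to compound 2. It places 4-fluorophenyl where 3-fluorophenyl stood and leaves the acetamido group untouched.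

Compound 3 (`COc1c(-c2cccc(F)c2)oc2ccc(N)cc2c1=O`) has not yet been measured. It differs from compound 1 in one place: hydrogen in place of acetyl on a nitrogen on an aromatic ring. In words, hydrogen takes the place of acetyl on a nitrogen on an aromatic ring, so acetamido becomes amino. For the measured compounds named here, no measured step covers this change, so the data give it no size. Compound 1 offers only a limit as a starting point, so any visible change would have to be a move to a lower number, meaning stronger inhibition. A modest move of that kind is expected, and compound 3 may well stay at the limit. The estimated change is an at least 1.7-fold lower number from compound 1 to compound 3 (0.25 log units; that floor lies within the scatter). For compound 3 the estimate is 70000 nM, with an expected range from 15000 nM to 125000 nM.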

Compound 3, half-maximal inhibitory concentration: 34000 nM
Compound 3: middle estimate off by 2.1-fold (0.31 log units), on the high side; measured number inside the range.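

Until this result, every compound shown carried the acetamido group and none gave a readable number, so nothing showed whether a change at this nitrogen could shift the read-out at all: the limit of > 125000 nM in this assay, at which 2 of the 3 values shown sit. Among the compounds shown here, replacing acetyl with hydrogen on the nitrogen on an aromatic ring gives the first true number in this assay, and the step is an at least 3.6-fold lower number from compound 1 to compound 3 (0.56 log units; beyond the scatter). This shows that the change from acetamido to amino can bring the compound down off the limit toward stronger inhibition, and the real size of the step could be larger than this floor, since its starting point is only a limit.

One open question is whether the free amino group itself matters or only the loss of acetyl, and other groups on this nitrogen, such as a methyl group, a longer propionyl chain or a methanesulfonyl group, are not among the compounds shown. From the compounds shown here alone, it also remains open whether the same change would lower the number with the 4-fluorophenyl group of compound 2, since only the 3-fluorophenyl group appears here alongside amino.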